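Moving the bromine on a chalcone-type antiproliferative

The source may hold more compounds than are shown below. What is called first, only, known or untested is meant among the compounds shown, and "the series" means these compounds.

Measured so far in a functional assay on PC-3 cells (Homo sapiens) for antiproliferative activity, read by MTT assay, with a stated time of 72 h; a lower number here means a stronger inhibitor, a higher number a weaker inhibitor:
- compound 1 `O=C(COc1ccc(C(=O)/C=C/c2cccc([N+](=O)[O-])c2)cc1)N[C@H]1CCOC1=O` gives 56300 nM
- compound 2 `O=C(COc1ccc(C(=O)/C=C/c2ccccc2Br)cc1)N[C@H]1CCOC1=O` gives 3260 nM

Among the measured compounds shown here, compound 2 has the lowest number of the two, and its only neighbour is compound 1, separated by a 17-fold lower number from compound 1 to compound 2 (1.24 log units; beyond the scatter), a change that rests on swapping a 3-nitrophenyl for a 2-bromophenyl on the double-bonded chain carbon.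

Compound 3 `O=C(COc1ccc(C(=O)/C=C/c2ccc(Br)cc2)cc1)N[C@H]1CCOC1=O` is not yet measured. It differs from compound 2 in one place only: 4-bromophenyl in place of 2-bromophenyl on a double-bonded chain carbon bound to a double-bonded chain carbon. The bromine-bearing ring stays a bromophenyl; only the point where the bromine sits on that ring moves.

For the measured compounds named here, the single measured step, a 17-fold lower number from compound 1 to compound 2 (1.24 log units; beyond the scatter), exchanged both the substituent and its place, so it does not isolate what shifting a bromine alone does. Going by the values given here, no measured pair separates that effect. With nothing pointing one way, compound 3 is expected to land near compound 2, with a step of a 1.2-fold higher number from compound 2 to compound 3 (0.09 log units; within the scatter) that stays within the usual scatter. Compound 3 is therefore estimated at 4000 nM, within a range from 1300 nM to 12000 nM.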

Compound 3, half-maximal inhibitory concentration: > 64000 nM
Compound 3: only a limit was reported; the forecaster's own chance of this, stated with the estimate: 3%; middle value at least 16-fold (1.20 log units) from the limit.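

In this assay, compound 3 gives only a limit of the assay and not a number: the limit of > 64000 nM in this assay, at which 1 of the 3 values shown sits.

Even so, moving the bromine alone, with the same atoms joined differently, gives an at least 19-fold higher number from compound 2 to compound 3 (1.29 log units; beyond the scatter), so on this double-bonded chain carbon the place of the bromine on the ring changes the reading, not only its presence. Set against the 3-nitrophenyl group, the 4-bromophenyl group gives an at least 1.1-fold higher number from compound 1 to compound 3 (0.05 log units; that floor lies within the scatter), so among the three compounds a bromophenyl group does not by itself bring the low number, which appears only with the 2-bromophenyl group.

From the compounds shown here alone, what stays open is whether the low number of compound 2 depends on bromine itself or would also appear with another group in its place on the ring, such as an amine or a carboxylic acid. Going by these compounds, the full size of the step to compound 3 also stays open, since only its floor is known.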